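Fluoro in Place of Methoxy on the Ester Aryl Ring

This account rests on a few compounds, and the source may have more. Where it says the series, first, only, none or still open, it means among the compounds named here.

The measured compounds in an ADME assay on Vero cells (Chlorocebus sabaeus) for cytotoxicity, read by MTT assay, with a stated time of 48 h; a higher number here means a weaker inhibitor, a lower number a stronger inhibitor:
compound 1, `O=C(NC1CCC(CN2CCN(c3cc(=O)c4cc(C(F)(F)F)cc([N+](=O)[O-])c4s3)CC2)CC1)c1ccccc1`, gives 44.3 ug/mL.
compound 2, `O=C(OC1CCC(CN2CCN(c3cc(=O)c4cc(C(F)(F)F)cc([N+](=O)[O-])c4s3)CC2)CC1)c1ccc(C(F)(F)F)cc1`, gives a limit of the assay, > 64 ug/mL.
compound 3, `COc1cccc(C(=O)OC2CCC(CN3CCN(c4cc(=O)c5cc(C(F)(F)F)cc([N+](=O)[O-])c5s4)CC3)CC2)c1`, gives a limit of the assay, > 64 ug/mL.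

Compound 3 thus stands at the limit of this assay rather than at a number, as does compound 2, so only compound 1 offers a read number. The step of an at least 1.4-fold higher number from compound 1 to compound 3 (0.15 log units; that floor lies within the scatter) has a floor within the scatter, and the step that the two limits leave unreadable from compound 2 to compound 3 cannot be read at all, since both ends sit at the limit of > 64 ug/mL in this assay, at which 2 of the 3 values shown sit.

Compound 4, `O=C(OC1CCC(CN2CCN(c3cc(=O)c4cc(C(F)(F)F)cc([N+](=O)[O-])c4s3)CC2)CC1)c1cccc(F)c1`, differs from compound 3 by fluoro in place of methoxy on an aromatic carbon. Neither measured step bears directly on this exchange, and none shows a movement beyond the scatter, so no step beyond the scatter is expected in this assay for compound 4. Compound 4 is therefore expected to lie near the limit again, with an estimate of 60 ug/mL in a range from 35 ug/mL to 100 ug/mL. The expected step from compound 3 is an at least 1.0-fold lower number from compound 3 to compound 4 (0.02 log units; that floor lies within the scatter).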

Compound 4, half-maximal inhibitory concentration: > 64 ug/mL
Compound 4: only a limit was reported (the forecaster's own chance of this, stated with the estimate: 65%); at least 1.0-fold (0.02 log units) between middle value and limit.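

In this assay compound 4 gives > 64 ug/mL, which is a limit of the assay and not a number. Fluoro in place of methoxy on this aromatic carbon thus leaves the compound at the same limit, but neither the step from compound 3 nor the step from compound 2 can be read, because both ends of each are limits: the limit of > 64 ug/mL in this assay, at which 3 of the 4 values shown sit.

Among these compounds, the one readable step, with ((3-fluorophenyl)carbonyl)oxy in place of benzamido, is an at least 1.4-fold higher number from compound 1 to compound 4 (0.15 log units; that floor lies within the scatter), so it shows no movement beyond the scatter.

As far as these compounds go, whether an amine or a carboxylic acid on this aromatic carbon would bring the ester series down to a read number remains open. Also open, from the compounds shown here alone, is how a 3-fluorophenyl amide would read against compound 1.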